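The source may report more compounds than this note shows. Statements on the series, on what has been measured and on what is new or still open speak of the compounds shown alone.

The measured compounds, all in a functional assay on cells (T-cell, Mus musculus) for inhibition; a lower number here means a stronger inhibitor, a higher number a weaker inhibitor:
Compound 1, `CC(=O)Oc1ccc(/C=C/C(=O)Nc2ccc3c(c2)COC3=O)cc1OC(C)=O`, gives 180 nM.
Compound 2, `O=C(Nc1ccccc1)Nc1ccc2c(c1)COC2=O`, gives 7090 nM.
Compound 3, `CN(C(=O)Nc1ccc2c(c1)COC2=O)c1ccccc1`, reaches only the limit of the measurement, > 100000 nM.

Among the two numbers, compound 2 stands highest; compound 1 is the nearest, with a far lower number. Compound 3 sits at a limit, (the limit of > 100000 nM in this assay, at which 1 of the 3 values shown sits), so it offers no number to compare.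

Compound 4, `O=C(Nc1ccc(I)cc1)Nc1ccc2c(c1)COC2=O`, differs from compound 2 in one place: iodo in place of hydrogen on an aromatic carbon. Among the measured compounds shown here, the only measured step, an at least 14-fold higher number from compound 2 to compound 3 (1.14 log units; beyond the scatter), concerns a methyl in place of hydrogen on an amide-type nitrogen, a different part of the molecule, so it does not speak to an iodo on an aromatic carbon. For the measured compounds named here, no measured pair shows what this change does. The expectation for compound 4 is therefore a step within the scatter, a 1.6-fold lower number from compound 2 to compound 4 (0.20 log units; within the scatter), with wide uncertainty. Compound 4 is estimated at 4500 nM, in the range from 1000 nM to 20000 nM.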

Compound 4, half-maximal inhibitory concentration: 1370 nM
Estimate against measurement, compound 4: 3.3-fold (0.52 log units) above; measured number inside the range.
By their numbers in this assay, from the lowest: compound 1; then compound 4; then compound 2. At a limit, above all of these: compound 3.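

In this assay, the phenyl ring of compound 2 proves open to change: swapping phenyl for 4-iodophenyl gives a 5.2-fold lower number from compound 2 to compound 4 (0.71 log units; beyond the scatter), so an iodo on this aromatic carbon, para to a large group, improves inhibition modestly rather than harming it. Among the compounds shown here, the only single change seen before was the methyl on the amide-type nitrogen, which went the other way, so this is the first sign that one atom added at the far end of the molecule can lower the number. Nothing measured here explains why the iodo has this effect.

Whether this is special to iodo stays open, since the compounds shown hold no chloro, methoxy, amine or carboxylic acid at this carbon. Also open, from the compounds shown here alone, is what the iodo would do on the other carbons of the same ring.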